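Writhing test notes: amide variants of compound 1

This account rests on a few compounds, and the source may have more. Where it says the series, first, only, none or still open, it means among the compounds named here.

Measured compounds:
Compound 1 `COc1cc2c(cc1OC)C(CC(=O)O)CC2`: 44%
Compound 2 `CCCNC(=O)CC1CCc2cc(OC)c(OC)cc21`: 26.9%
Compound 3 `CCCCCCNC(=O)CC1CCc2cc(OC)c(OC)cc21`: 82.2%

In a functional assay on the whole organism (strain Swiss albino) for inhibition, with Mus musculus as the target, in the writhing test, with stated times of 60 min and 15 min, at a dose of 100 mg/kg by the oral route (a higher number here means more inhibition at the dose given (going by the name of the read-out), a lower number less inhibition), compound 1 gives 44% and stands second highest of the three numbers. The nearest is compound 2, reached by a number 17.1 percentage points lower from compound 1 to compound 2 (beyond the scatter); the furthest is compound 3, reached by a number 38.2 percentage points higher from compound 1 to compound 3 (beyond the scatter). Between the two amides the step is a number 55.3 percentage points higher from compound 2 to compound 3 (beyond the scatter).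

Compound 4 `COc1cc2c(cc1OC)C(CC(=O)N1CCOCC1)CC2` is not yet measured. It differs from compound 1 by morpholin-4-yl in place of hydroxy on a carbonyl carbon. Both measured steps from compound 1 concern the same carbonyl carbon and bear on it: the propylamino step was modest and downward, the hexylamino step large and upward. The two do not point the same way, so no single direction follows, and with a cyclic amine of few heavy atoms entering, a step near the scatter or modestly in either direction is expected rather than a large one. Compound 4 is therefore expected to give 40%, between 18% and 68%, that is an expected step of a number 4 percentage points lower from compound 1 to compound 4 (within the scatter) in this assay.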

Compound 4, a percentage reported as inhibition, in the whole organism at one dose (the size of the read-out at that dose, not a potency): 23.6%
Beside the measured number, compound 4's estimate is 16.4 percentage points above it, within the range that was stated.
By their numbers in this assay, from the lowest: compounds 4 and 2 (each within the scatter of the next); then compound 1; then compound 3.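

In this assay, morpholin-4-yl on the carbonyl carbon costs inhibition relative to hydroxy (a number 20.4 percentage points lower from compound 1 to compound 4 (beyond the scatter)), and it gives a result that cannot be told apart from propylamino (a number 3.3 percentage points lower from compound 2 to compound 4 (within the scatter)). The gap to hexylamino is large (a number 58.6 percentage points lower from compound 3 to compound 4 (beyond the scatter)), so of the three amide groups shown only hexylamino stands above the acid, while compound 2 and compound 4 go against any general gain from replacing hydroxy at this carbon. No measurement available here accounts for these steps.

Open, going by these compounds, is whether an octylamino chain extends the gain seen with hexylamino or loses it, and where butylamino falls between propylamino and hexylamino. Also open, on these data alone, is whether piperidin-1-yl, the ring without its oxygen, stays level with morpholin-4-yl.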